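Chloro for Nitro in a Shared Core

The source may hold more compounds than are shown below. What is called first, only, known or untested is meant among the compounds shown, and "the series" means these compounds.

The three measured compounds share one core. Compound 1 `Cc1ccc2[nH]c(=O)c(-c3nc4cc([N+](=O)[O-])ccc4[nH]3)cc2c1` carries a methyl and a nitro group. In a functional assay on NCI-H460 cells (Homo sapiens) for cytotoxicity, read by MTT assay, with a stated time of 48 h (a lower number here means a stronger inhibitor, a higher number a weaker inhibitor), compound 1 gives > 100000 nM, which is a limit of the assay and not a number. Compound 2 `O=c1[nH]c2ccccc2cc1-c1nc2cc([N+](=O)[O-])ccc2[nH]1` lacks the methyl. In this assay compound 2 gives > 100000 nM, again a limit of the assay. Compound 3 `Cc1ccc2[nH]c(=O)c(-c3nc4cc(Br)ccc4[nH]3)cc2c1` has bromo in place of nitro. In this assay compound 3 gives > 100000 nM, also a limit. Compound 2 thus stands at the same limit as the other two, (the limit of > 100000 nM in this assay, at which 3 of the 3 values shown sit). The step that the two limits leave unreadable from compound 1 to compound 2 and the step that the two limits leave unreadable from compound 1 to compound 3 are accordingly unreadable in size. Compound 4 `O=c1[nH]c2ccccc2cc1-c1nc2cc(Cl)ccc2[nH]1` differs from compound 2 by chloro in place of nitro on an aromatic carbon. For the measured compounds named here, the one measured step that bears on this exchange, bromo for nitro from compound 1 to compound 3, left no readable size, so no step beyond the scatter can be expected in either direction. Compound 4 is therefore expected to give 100000 nM in this assay, with a range from 30000 nM to 300000 nM, most likely again as a limit. The step of a number no higher from compound 2 to compound 4 (the limit leaves the size open) is estimated to stay within the scatter.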

Compound 4, half-maximal inhibitory concentration: 14700 nM
Compound 4: the middle estimate sits 6.8-fold (0.83 log units) above what was measured; measured number below the stated range.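

For the compounds shown here, on an aromatic carbon of the shared core, chloro in place of nitro gives the first readable change in this assay, an at least 6.8-fold lower number from compound 2 to compound 4 (0.83 log units; beyond the scatter), so this position does respond to an exchange of group, which the earlier steps could not show. In this assay, on these data alone, compound 2 gives > 100000 nM, which is a limit of the assay and not a number, so the full size of this step stays open. Compound 4 is the only compound shown with a readable number, and the others all stand at one limit: the limit of > 100000 nM in this assay, at which 3 of the 4 values shown sit.

The compounds shown leave open whether chloro also lowers the number on the core of compound 1, which carries the methyl. They also leave open whether an amine, a methoxy group or plain hydrogen at this position would give a readable number.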